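This account rests on a few compounds, and the source may have more. Where it says the series, first, only, none or still open, it means among the compounds named here.

Compound 1 `Cc1ccc(NC2=CC(=O)c3nc4n(c3C2=O)[C@H]2OC[C@@H](O)[C@H]2OC4)cc1C` carries a 3,4-dimethylphenyl on an amine nitrogen of the shared core. In a functional assay on MGC-803 cells (Homo sapiens) for inhibition, read by sulforhodamine B assay (a higher number here means a weaker inhibitor, a lower number a stronger inhibitor), compound 1 gives 860 nM, the lowest of the two numbers in hand. Compound 3 `O=C1C(Nc2ccccc2)=CC(=O)c2c1nc1n2[C@H]2OC[C@@H](O)[C@H]2OC1`, which bears a plain phenyl on that nitrogen, gives 1830 nM in this assay. Compound 2 `O=C1C(NC2CCCCC2)=CC(=O)c2c1nc1n2[C@H]2OC[C@@H](O)[C@H]2OC1`, with a cyclohexyl on the same nitrogen, reaches only a limit of this assay, > 8000 nM, and no number. Compound 2 thus sits at the limit of > 8000 nM in this assay, at which 1 of the 3 values shown sits. Going by the values given here, the one step on record, an at least 4.3-fold lower number from compound 2 to compound 3 (0.64 log units; beyond the scatter), shows that an aromatic group on that nitrogen is favoured over the saturated one. Compound 4 `O=C1C=C(Nc2ccccc2F)C(=O)c2c1nc1n2[C@H]2OC[C@@H](O)[C@H]2OC1` has not yet been measured; it differs from compound 1 by 2-fluorophenyl in place of 3,4-dimethylphenyl on an amine nitrogen. Among the compounds with values here, no measured step covers the exchange of one aryl for another; the values of compound 1 and compound 3 show that losing the two methyls raised the number modestly, and the fluorine is the only addition here. Compound 4 is therefore expected to show a 1.7-fold higher number from compound 1 to compound 4 (0.24 log units; within the scatter). The estimate for compound 4 is 1500 nM, within 600 nM to 4000 nM.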

Compound 4, half-maximal inhibitory concentration: 2080 nM
Estimate against measurement, compound 4: 1.4-fold (0.14 log units) below; measured number inside the range.
By their numbers in this assay, from the lowest: compound 1; then compounds 3 and 4 (each within the scatter of the next). At a limit, above all of these: compound 2.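

Exchanging one aryl group for another on this amine nitrogen also moves the number, a change the earlier step from a saturated to an aromatic group did not cover: a 2.4-fold higher number from compound 1 to compound 4 (0.38 log units; beyond the scatter). In this assay compound 3 gives 1830 nM and compound 4 gives 2080 nM, two values within the scatter of each other, so the plain phenyl and the 2-fluorophenyl cannot be told apart here. Nothing measured in this set gives a cause for the step.

The compounds shown leave open how a phenyl carrying a single methyl, a methoxy or a chlorine would read in this assay, and so whether both methyls of the 3,4-dimethylphenyl are needed. They also leave open how a benzyl group or a pyridine ring on that nitrogen would compare.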